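The compounds below may be only part of what the source reports. "The series", "measured", "known", "first", "only" and "open" are said of these compounds alone.

Of the compounds shown here, two have so far been measured in a functional assay on ACHN cells (Homo sapiens) for inhibition, read by sulforhodamine B assay, with a stated time of 48 h; a higher number here means a weaker inhibitor of growth, a lower number a stronger inhibitor of growth. Compound 1, `N#C/C(=C\N1CCN(C(=O)c2ccco2)C1=S)C(=O)Nc1ccc(Cl)cc1`, gives 15300 nM in this assay. Compound 2, `O=CN1CCN(c2ccc(Cl)cc2)C1=S`, gives 17300 nM in this assay; of the two numbers this is the higher, but the gap to compound 1 is within the scatter of repeated measurements, so both compounds show weak inhibition of growth of about the same strength. Compound 3, `O=CN1CCN(c2ccc(Cl)c(Cl)c2)C1=S`, has not yet been measured. It differs from compound 2 in one place: chloro in place of hydrogen on an aromatic carbon. Within the data shown here, no measured pair of compounds shows what this change does in this assay, so the expectation can rest only on the value of compound 2. The change is expected to bring a step of about a 1.2-fold lower number from compound 2 to compound 3 (0.09 log units; within the scatter), which would stay within the usual scatter. On that basis compound 3 is estimated to give 14000 nM in this assay, with a likely range from 5000 nM to 40000 nM.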

Compound 3, concentration for 50% growth inhibition: 17300 nM
Beside the measured number, compound 3's estimate is 1.2-fold (0.09 log units) below it; measured number inside the range.
By their numbers in this assay, from the lowest: compounds 1, 2 and 3 (each within the scatter of the next).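

Among these compounds, this is the first direct reading of a change on the aromatic ring: in this assay, putting chloro in place of hydrogen on this aromatic carbon, ortho to a chloro group, gives no change at the digits printed from compound 2 to compound 3 (within the scatter). This position therefore takes one extra chlorine with no shift that can be told from the scatter, and growth inhibition stays weak. No available measurement bears on the reason for this result.

On these data alone, whether a different group on this carbon, such as a methoxy group, an amine or a carboxylic acid, would move the number beyond the scatter remains open. As far as these compounds go, it is also open whether the same chloro change would read the same on another carbon of this ring, or on the core of compound 1.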